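The compounds below may be only part of what the source reports. "The series", "measured", "known", "first", "only" and "open" are said of these compounds alone.

In a functional assay on A549 cells (Homo sapiens) for cytotoxicity, read by MTT assay, with a stated time of 72 h (on this read-out lower numbers stand for stronger inhibition and higher numbers for weaker inhibition), compound 3, `Cc1cc(=O)n(-c2ccc(F)cc2)nc1C(=O)Nc1ccc(Oc2ncnc3[nH]ccc23)cc1`, gives only a limit of the assay rather than a number, > 60000 nM. That limit is the one described by the limit of > 60000 nM in this assay, at which 2 of the 3 values shown sit. For comparison, compound 1, `O=C(Nc1ccc(Oc2ccnc3[nH]ccc23)c(F)c1)c1nn(-c2ccc(Br)cc2)ccc1=O`, also gives only a limit in this assay, > 60000 nM. Compound 2, `O=C(Nc1ccc(Oc2ccnc3[nH]ccc23)c(F)c1)c1nn(-c2ccc(Cl)c(F)c2)ccc1=O`, gives a true number in this assay, 10300 nM. Among the measured compounds shown here, the one measured step, an at least 5.8-fold lower number from compound 1 to compound 2 (0.76 log units; beyond the scatter), shows that swapping halogens on the ring attached to the aromatic nitrogen can move a compound from the limit into the measurable range.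

Compound 4, `Cc1cc(=O)n(-c2cccc(F)c2)nc1C(=O)Nc1ccc(Oc2ncnc3[nH]ccc23)cc1`, is the next compound to be measured. Its change from compound 3 is 3-fluorophenyl in place of 4-fluorophenyl on an aromatic nitrogen. This is a smaller change than the measured step, since the same atoms are simply joined differently, and compound 3 starts at the limit. The expected step, an at least 1.2-fold lower number from compound 3 to compound 4 (0.07 log units; that floor lies within the scatter), is therefore small and may not be seen at all if compound 4 also sits at the limit. The estimate for compound 4 in this assay is 50000 nM, with a plausible range from 12000 nM to 200000 nM, and a real chance that only a limit is reported.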

Compound 4, half-maximal inhibitory concentration: 34800 nM
Beside the measured number, compound 4's estimate is 1.4-fold (0.16 log units) above it; the range from low to high includes it.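

In this assay, 3-fluorophenyl in place of 4-fluorophenyl on the aromatic nitrogen gives an at least 1.7-fold lower number from compound 3 to compound 4 (0.23 log units; that floor lies within the scatter). The earlier step changed which halogens the ring carried, whereas this one keeps the same atoms and moves only the fluorine, and compound 4 gives a true number where compound 3 does not, which suggests that the place of a single fluorine on this ring may matter, though the floor of the step does not show this by itself. Compound 3 gives only a limit, > 60000 nM, so the full size of the step cannot be read and only its floor is known, and compound 3 is not alone at that limit: the limit of > 60000 nM in this assay, at which 2 of the 4 values shown sit.

The compounds shown leave open how 2-fluorophenyl would compare on the same core, and whether a different group at this place on the phenyl ring, such as a methoxy group, an amine or a carboxylic acid, would give a lower number than compound 4 does. They also leave open whether moving the fluorine has a similar result on the core of compound 1, since no pair shown tests this.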